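From 4-fluorophenyl to 2,4-difluorophenyl in compound 3

A few compounds are considered here, and "the series" means these few. Any claim that something is new, unique, unknown or untested is made for them only; others in the source may bear on it.

- Compound 1 `CC1(COc2cccc(-c3ccc(F)nc3)n2)CCn2cc([N+](=O)[O-])nc2O1` gives > 64000 nM
- Compound 2 `CC1(COc2cccc(-c3ccc(F)cc3)n2)CCn2cc([N+](=O)[O-])nc2O1` gives > 64000 nM

In an ADME assay on MRC5 cells (Homo sapiens) for cytotoxicity, read by resazurin assay, with a stated time of 72 h (on this read-out lower numbers stand for stronger inhibition and higher numbers for weaker inhibition), compound 2 gives > 64000 nM, which is a limit of the assay and not a number. Compound 1 also stands at a limit, with > 64000 nM. The data so far therefore consist of the limit of > 64000 nM in this assay, at which 2 of the 2 values shown sit. For the measured compounds named here, the only measured step is a step that the two limits leave unreadable from compound 1 to compound 2, with 4-fluorophenyl in place of 6-fluoropyridin-3-yl on an aromatic carbon.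

Compound 3 `CC1(COc2cccc(-c3ccc(F)cc3F)n2)CCn2cc([N+](=O)[O-])nc2O1` differs from compound 2 by one change: fluoro in place of hydrogen on an aromatic carbon. This is fluoro in place of hydrogen on an aromatic carbon, ortho to a large group and meta to a fluoro group, so 4-fluorophenyl becomes 2,4-difluorophenyl.

Going by the values given here, the one measured step has no readable size, so it offers no direction, and no shift beyond the scatter is expected in this assay. The estimated change is a number no higher from compound 2 to compound 3 (the limit leaves the size open). For compound 3 the expected value is 64000 nM, with an estimated range from 30000 nM to 128000 nM.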

Compound 3, half-maximal inhibitory concentration: > 64000 nM
Compound 3 ended at the assay's limit (the forecaster's own chance of this, stated with the estimate: 85%); the middle value sits exactly at the limit.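

In this assay compound 3 gives > 64000 nM, which is a limit of the assay and not a number. No step among compound 1, compound 2 and compound 3 can be read: the limit of > 64000 nM in this assay, at which 3 of the 3 values shown sit.

The compounds shown leave open at what concentration, if any, each of the three would reach half-maximal inhibition, and so whether the added fluoro changes anything.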